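The compounds below may be only part of what the source reports. "The series", "measured", "known", "first", "only" and "open" are said of these compounds alone.

Working notes on the chalcone series in a functional assay on HaCaT cells (Homo sapiens), read by fluorescence and BrdU incorporation, with a stated time of 48 h, tested at 25 uM; on this read-out higher numbers stand for a weaker effect at the one concentration tested and lower numbers for a stronger effect.

Three compounds have numbers or a verdict in this assay. Compound 2 `COc1cccc(/C=C/C(=O)c2c(OC)cc(OC)cc2OC)c1` gives 0%. Compound 3 `COc1cc(OC)c(C(=O)/C=C/c2ccc(F)cc2)c(OC)c1` gives 0.4%. Compound 1 `COc1cc(O)c(C(=O)/C=C/c2ccc(F)cc2)c(OC)c1` is recorded as "not active" (no number reported) without a number. On the numbers shown, compound 2 holds the lower of the two reported values, but the step of a number 0.4 percentage points higher from compound 2 to compound 3 (within the scatter) lies within the scatter, so compound 2 and compound 3 cannot be told apart, and compound 1 adds no number to place against them.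

Compound 4 `COc1cc(OC)c(C(=O)/C=C/c2ccc(Br)cc2)c(OC)c1` is the next member to be run. Relative to compound 2 it differs as follows: 4-bromophenyl in place of 3-methoxyphenyl on a double-bonded chain carbon bound to a double-bonded chain carbon

Going by the values given here, the one measured step that bears on this change is the step from compound 2 to compound 3, which puts 4-fluorophenyl at the same place and amounts to a number 0.4 percentage points higher from compound 2 to compound 3 (within the scatter), within the scatter. The shared core with three methoxy groups is kept in compound 4. Among the compounds with values here, nothing measured so far points to a step beyond the scatter for a halogen at this place. Compound 4 is therefore expected to sit near the floor of the read-out, with an estimated step of a number 1 percentage points higher from compound 2 to compound 4 (within the scatter). The estimate for compound 4 is 1%, with a range from 0% to 8%.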

Compound 4, a percentage reported as activity, at one concentration (the size of the read-out at that concentration, not a potency): 0.3%
Estimate against measurement, compound 4: 0.7 percentage points above; the measured number falls inside the stated range.
By their numbers in this assay, from the lowest: compounds 2, 4 and 3 (each within the scatter of the next).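

In this assay, replacing 3-methoxyphenyl with 4-bromophenyl on a double-bonded chain carbon bound to a double-bonded chain carbon gives a number 0.3 percentage points higher from compound 2 to compound 4 (within the scatter), so a second halogen-bearing phenyl group at this place joins 4-fluorophenyl without a step beyond the scatter. The series now also holds a direct exchange of one halogen for another, bromo in place of fluoro on an aromatic carbon, and this gives a number 0.1 percentage points lower from compound 3 to compound 4 (within the scatter), so compound 2, compound 3 and compound 4 cannot be told apart in this read-out. No measured evidence bears on why this position shows no separation among these three groups.

From the compounds shown here alone, whether this position stays flat for groups of another kind, such as an amine or a carboxylic acid in place of the halogen, remains open. Compound 1 carries a verdict and no number, so the step from it to compound 3 cannot be read, and the effect of changing the shared core also remains unresolved.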